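Lengthening the Thiourea Chain: Compound 2 to Compound 3

The compounds below may be only part of what the source reports. "The series", "measured", "known", "first", "only" and "open" are said of these compounds alone.

Compound 1, `C/C(=N\c1nc2ccc(OC(F)(F)F)cc2s1)N(C)C`, gives 0.1 uM in a functional assay on Cortex (Rattus norvegicus, strain Sprague-Dawley), read by LDH release; on this read-out higher numbers stand for an effect only at larger amounts of compound and lower numbers for an effect already at smaller amounts.
Compound 2, `CCNC(=S)Nc1nc2ccc(OC(F)(F)F)cc2s1`, gives 0.1 uM in this assay.

Compound 2 stands level with compound 1 on these numbers. Among the measured compounds shown here, the single step measured so far, no change at the digits printed from compound 1 to compound 2 (within the scatter), exchanged one acyclic group for another on an aromatic carbon of the shared core and left the read-out unchanged within the scatter.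

Compound 3, `CCCNC(=S)Nc1nc2ccc(OC(F)(F)F)cc2s1`, has not yet been measured in this assay. It differs from compound 2 by methyl in place of hydrogen on a saturated chain carbon, two bonds along the chain from an amide-type nitrogen. For the measured compounds named here, no measured step touches this chain; the only step available, no change at the digits printed from compound 1 to compound 2 (within the scatter), concerns a different exchange and in any case showed no change. There is thus nothing in the data pointing to a shift in either direction, and the step from compound 2 to compound 3 is expected to stay within the scatter: no change at the digits printed from compound 2 to compound 3 (within the scatter). Compound 3 is therefore estimated at 0.1 uM in this assay, with a range from 0.03 uM to 0.3 uM.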

Compound 3, minimum effective concentration: 0.01 uM
Beside the measured number, compound 3's estimate is 10-fold (1.00 log units) above it; measured number outside the range, below it.
By their numbers in this assay, from the lowest: compound 3; then compounds 1 and 2 (each within the scatter of the next).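

Within this assay, going from ethyl to propyl, methyl in place of hydrogen on a saturated chain carbon, two bonds along the chain from an amide-type nitrogen, gives a 10-fold lower number from compound 2 to compound 3 (1.00 log units; beyond the scatter) and is the first step in this set to lie beyond the scatter. The earlier exchange on the aromatic carbon, no change at the digits printed from compound 1 to compound 2 (within the scatter) in the read-out, gave no sign that this chain could move the number, whereas the propyl-bearing group now gives a 10-fold lower number from compound 1 to compound 3 (1.00 log units; beyond the scatter) as well, so compound 3 sits apart from both compound 1 and compound 2 and the chain end emerges as a place where the addition of one methyl registers in this assay. The data offer no measurement that would explain why this small extension shifts the read-out.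

What the compounds shown leave open is whether the trend carries on to a butyl or longer chain, or whether propyl is already the best length. They also leave open how a branched isopropyl group, a cyclopropyl ring or a hydroxyl at the chain end would read at this same position.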